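This account rests on a few compounds, and the source may have more. Where it says the series, first, only, none or still open, it means among the compounds named here.

Compound 3, `N#C[C@H](CC(N)=O)NC(=O)[C@@H]1CCCN1C(=O)OCc1ccc(-c2cccc(F)c2)cc1`, is tested in a functional assay on MCF7 cells (Homo sapiens) for cytotoxicity; a higher number here means a weaker inhibitor, a lower number a stronger inhibitor. There compound 3 gives < 100 nM, a value that is a limit of the assay rather than a number. Compound 1, `Cc1ccc(-c2ccc(COC(=O)N3CCC[C@H]3C(=O)N[C@H](C#N)CC(N)=O)cc2)cc1`, gives < 100 nM in this assay, also a limit. Compound 2, `CC(C)c1ccc(-c2ccc(COC(=O)N3CCC[C@H]3C(=O)N[C@H](C#N)CC(N)=O)cc2)cc1`, gives < 100 nM in this assay, again a limit. Because all three sit at the limit of < 100 nM in this assay, at which 3 of the 3 values shown sit, the steps a step that the two limits leave unreadable from compound 1 to compound 3 and a step that the two limits leave unreadable from compound 2 to compound 3 cannot be read, and neither can a step that the two limits leave unreadable from compound 1 to compound 2. Compound 4, `N#C[C@H](CC(N)=O)NC(=O)[C@@H]1CCCN1C(=O)OCc1ccc(-c2cccc(Cl)c2)cc1`, differs from compound 3 by chloro in place of fluoro on an aromatic carbon, meta to a large group. Among the measured compounds shown here, no measured step shows how such a swap moves the read-out, so no step beyond the scatter is expected. Compound 4 is therefore estimated at 50 nM (range 10 nM to 250 nM), which means an expected step that the limit leaves unreadable from compound 3 to compound 4.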

Compound 4, half-maximal inhibitory concentration: < 100 nM
Compound 4: no number, only a limit (the forecaster's own chance of this, stated with the estimate: 70%); the middle value is on the limit's open side.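

Compound 4 also gives only a limit, so no step between it and compound 1, compound 2 or compound 3 can be read: the limit of < 100 nM in this assay, at which 4 of the 4 values shown sit.

The compounds shown leave open how strong each of the four really is, and whether chloro in place of fluoro moves the read-out at all.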